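From methoxy to methyl on the aromatic ring

The source may hold more compounds than are shown below. What is called first, only, known or untested is meant among the compounds shown, and "the series" means these compounds.

Measured in a functional assay on THP-1 cells (Homo sapiens) for cytotoxicity, read by MTT assay, with a stated time of 72 h (a higher number here means a weaker inhibitor, a lower number a stronger inhibitor), the compounds read as follows
Compound 1 `C=C1CC[C@H]2C(C)(C)CCC[C@]2(C)[C@H]1CCC(C)CC(=O)OC` gives > 200000 nM as a limit
Compound 2 `COc1ccc(/C=C2\CC[C@H]3C(C)(C)CCC[C@]3(C)[C@H]2CCC(C)CC(=O)O)cc1` gives > 200000 nM as a limit

Compound 2 has no number of its own in this assay and holds only a limit. Within the data shown here, the whole series so far is summed up by the limit of > 200000 nM in this assay, at which 2 of the 2 values shown sit, and nothing more. Compound 3 `Cc1ccc(/C=C2\CC[C@H]3C(C)(C)CCC[C@]3(C)[C@H]2CCC(C)CC(=O)O)cc1` carries methyl in place of methoxy on an aromatic carbon so that 4-methoxyphenyl becomes 4-methylphenyl. Among the measured compounds shown here, no measured pair shows what such a change does, and no step beyond the scatter is expected in this assay here. This expectation rests on compound 2 with its limit > 200000 nM and on nothing else. The expected step is a number no higher from compound 2 to compound 3 (the limit leaves the size open) in this reading. For compound 3 the estimated value is 200000 nM with an expected range from 90000 nM to 400000 nM and a good chance that only a limit will result.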

Compound 3, half-maximal inhibitory concentration: 91000 nM
The estimate for compound 3 lay 2.2-fold (0.34 log units) above the measured number; measured number inside the range.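

In this assay, replacing 4-methoxyphenyl with 4-methylphenyl gives an at least 2.1-fold lower number from compound 2 to compound 3 (0.34 log units; beyond the scatter), so what sits on this aromatic carbon, para to a large group, can change the read-out. Neither earlier compound could show this, and compound 3 is the only one of the three to give a number rather than a limit. The step can be stated only as a minimum, and its true size stays open, because compound 2 holds only a limit: the limit of > 200000 nM in this assay, at which 2 of the 3 values shown sit.

The compounds shown leave open whether a hydroxyl group, a chlorine atom or an amine on this carbon would lower the number further, or whether a longer chain such as ethyl would do the same as methyl. They also do not tell whether the step would persist with a different group at the other end of the molecule.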